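Aryl variation on the shared core: notes toward compound 4

A few compounds are considered here, and "the series" means these few. Any claim that something is new, unique, unknown or untested is made for them only; others in the source may bear on it.

Compound 1 `Cc1cc(O)c(C(C)C)cc1-c1cc(-c2cccs2)c(C#N)c(=O)[nH]1` gives 54.3% in a functional assay for inhibition, tested at 60 ug/mL; a higher number here means a stronger effect of the compound at the concentration tested, a lower number a weaker effect.
Compound 2 `COc1ccc(-c2cc(-c3cc(C(C)C)c(O)cc3C)[nH]c(=O)c2C#N)cc1` gives 43% in this assay.
Compound 3 `Cc1cc(O)c(C(C)C)cc1-c1cc(-c2ccco2)c(C#N)c(=O)[nH]1` gives 55.2% in this assay.

Compound 3 stands highest of the three numbers, but the gap to compound 1, a number 0.9 percentage points higher from compound 1 to compound 3 (within the scatter), lies within the scatter, so no order between compound 1 and compound 3 is claimed. The gap to compound 2 is beyond the scatter: a number 12.2 percentage points higher from compound 2 to compound 3 (beyond the scatter). The same picture appears in a number 11.3 percentage points lower from compound 1 to compound 2 (beyond the scatter): in both measured steps the 4-methoxyphenyl compound sits a modest amount lower than a five-membered heteroaryl compound.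

Compound 4 `COc1ccc(-c2cc(-c3cc(C(C)C)c(O)cc3C)[nH]c(=O)c2C#N)cc1OC` differs from compound 3 in one place: 3,4-dimethoxyphenyl in place of furan-2-yl on an aromatic carbon. The step that bears on it most directly is a number 12.2 percentage points higher from compound 2 to compound 3 (beyond the scatter), which runs the opposite way, from a methoxyphenyl to a furan-2-yl group. Among the measured compounds shown here, no measured step covers the second methoxy group; the only guide is compound 2, which with its 4-methoxyphenyl group gives 43% in this assay.

A modest drop of comparable size, a number 12.2 percentage points lower from compound 3 to compound 4 (beyond the scatter), is therefore expected for compound 4. Compound 4 is estimated at 43% in this assay, with a range from 30% to 56%.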

Compound 4, a percentage reported as inhibition, at one concentration (the size of the read-out at that concentration, not a potency): 52%
Compound 4: the middle estimate sits 9 percentage points below what was measured; the range from low to high includes it.
By their numbers in this assay, from the lowest: compounds 2, 4, 1 and 3 (each within the scatter of the next, the first and the last beyond it).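

In this assay, a six-membered aromatic ring at this position is no longer set apart from the five-membered heteroaryl groups. The 3,4-dimethoxyphenyl group gives a number 3.2 percentage points lower from compound 3 to compound 4 (within the scatter) against furan-2-yl and a number 2.3 percentage points lower from compound 1 to compound 4 (within the scatter) against thiophen-2-yl, so compound 4 goes against any reading of the lower number of compound 2 as a general mark of six-membered aromatic rings here. The added methoxy gives a number 9 percentage points higher from compound 2 to compound 4 (within the scatter), so no effect can be assigned to it, even though the gaps from compound 2 to compound 1 and to compound 3 lie beyond the scatter while those from compound 4 do not. The compounds shown offer no independent data that could explain these numbers.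

All the groups shown at this position are aromatic rings, and the only substituent on the phenyl rings is methoxy, so it remains open how a cyclohexyl ring, a longer alkyl chain, or a phenyl ring carrying an amine or a carboxylic acid would read. Each read-out also comes from a single concentration, so these numbers speak only of a stronger or weaker effect at that concentration.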